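This account rests on a few compounds, and the source may have more. Where it says the series, first, only, none or still open, it means among the compounds named here.

Measured so far:
Compound 1, `CC(=O)N[C@@H]1CCCc2c1cncc2N1CCc2cc(Cl)ccc2C1=O`, in an ADME assay on microsomes from liver (Homo sapiens) for metabolic stability, read by LC-MS, using NADPH, with stated times of 10 min and 30 min (a lower number here means slower removal, a higher number faster removal of the compound), gives 4.3 mL/min/kg.
Compound 2, `CCC(=O)N[C@@H]1CCCc2c1cncc2N1C(=O)c2ccc(Cl)cc2[C@@H]1C`, in this assay gives only a limit, < 3.5 mL/min/kg.
Compound 3, `CCC(=O)N[C@@H]1CCCc2c1cncc2N1CCc2cc(Cl)ccc2C1=O`, in this assay gives only a limit, < 3.5 mL/min/kg.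

Compound 1 and compound 3 share a core; how it differs from the core of compound 2 is not broken down here. The change from compound 1 to compound 3 is methyl in place of hydrogen on a saturated chain carbon bound to a carbonyl carbon, and in this assay it gives an at least 1.2-fold lower number from compound 1 to compound 3 (0.08 log units; that floor lies within the scatter). That step is bounded by the limit of < 3.5 mL/min/kg in this assay, at which 2 of the 3 values shown sit. Compound 4, `CCC(=O)N[C@@H]1CCCc2c1cncc2N1C(=O)c2ccc(Cl)cc2[C@@H]1CC`, has not yet been measured. From compound 2 it differs by methyl in place of hydrogen on a saturated chain carbon bound to a saturated ring carbon: the same kind of change as from compound 1 to compound 3, though not the same, since the place here is a saturated chain carbon bound to a saturated ring carbon rather than one bound to a carbonyl carbon. Compound 2 already stands at the limit < 3.5 mL/min/kg, which leaves little room for a lower number. The step from compound 2 to compound 4 is therefore expected at a step that the limit leaves unreadable from compound 2 to compound 4. Compound 4 is expected at 3 mL/min/kg, within 1.5 mL/min/kg to 5.5 mL/min/kg, most likely reported again as a limit only.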

Compound 4, clearance: < 3.5 mL/min/kg
Compound 4 gave a limit, no number; the forecaster's own chance of this, stated with the estimate: 65%; the middle value is on the limit's open side.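

Compound 2 and compound 4 are both reported only as limits in this assay, so no step can be read between them: the limit of < 3.5 mL/min/kg in this assay, at which 3 of the 4 values shown sit.

The compounds shown leave open whether methyl to ethyl at this place changes clearance at all.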